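This account rests on a few compounds, and the source may have more. Where it says the series, first, only, none or still open, it means among the compounds named here.

Of the compounds shown here, two have so far been tested in a functional assay on A549 cells (Homo sapiens) for antiproliferative activity, with a stated time of 5 days; on this read-out lower numbers stand for stronger inhibition and higher numbers for weaker inhibition. Compound 1 `O=C1C=CC2(C=C1)OCC(=O)N2c1nc(-c2cccc3ccccc23)nn1-c1ccccc1` carries a naphthalen-1-yl group on the shared core, and in this assay compound 1 gives 80 nM. Compound 2 `CC1OC2(C=CC(=O)C=C2)N(c2nc(-c3ccc4ccccc4c3)nn2-c2ccccc2)C1=O` differs from it in two places at once, and in this assay compound 2 gives 310 nM. Compound 1 therefore holds the lower of the two numbers, and its gap to compound 2 lies beyond the usual scatter of repeated measurements.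

Compound 3 `O=C1C=CC2(C=C1)OCC(=O)N2c1nc(-c2cccc(Cl)c2)nn1-c1ccccc1` has not yet been measured. It differs from compound 1 in one place: 3-chlorophenyl in place of naphthalen-1-yl on an aromatic carbon. The group that leaves is the larger one, with two aromatic rings, and the group that enters has a single aromatic ring bearing a chlorine. For the measured compounds named here, no measured pair shows this exact change, so its effect cannot be read from the existing numbers. The expectation is that the number rises, by a step beyond the scatter, meaning somewhat weaker inhibition; the expected step is a 3.1-fold higher number from compound 1 to compound 3 (0.49 log units; beyond the scatter). Compound 3 is therefore estimated at 250 nM, with a likely range from 60 nM to 1000 nM.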

Compound 3, half-maximal inhibitory concentration: 25.2 nM
Compound 3: middle estimate off by 9.9-fold (1.00 log units), on the high side; measured number outside the range, below it.
By their numbers in this assay, from the lowest: compound 3; then compound 1; then compound 2.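

In this assay, the position on the five-membered aromatic ring that holds naphthalen-1-yl in compound 1 turns out not to need two aromatic rings: 3-chlorophenyl, the smaller group with a single aromatic ring bearing a chlorine, gives a 3.2-fold lower number from compound 1 to compound 3 (0.50 log units; beyond the scatter), a step beyond the usual scatter towards stronger inhibition. For the compounds shown here, this is the first change at this position that can be read alone, since the two earlier compounds differ in two places at once. No measurement at hand bears on why the number moves in this direction.

The step removes a ring and adds a chlorine together, so the two contributions cannot be separated from these compounds; a plain phenyl group at this position would show how much of the step belongs to the chlorine. On these data alone, it also remains open whether the chlorine itself matters or whether another small group in its place, such as a fluorine, a methyl or a methoxy group, would give a similar number on the same core.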